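Oxazole series: aryl change from compound 1 to compound 4

This account rests on a few compounds, and the source may have more. Where it says the series, first, only, none or still open, it means among the compounds named here.

Compound 1 `Cc1cc(C)c(-c2nc(CN3CCC(C(=O)NCCCN4C[C@H](C)C[C@H](C)C4)CC3)c(C)o2)c(C)c1` is followed in an ADME assay on microsomes from liver (Rattus norvegicus) for metabolic stability, read by LC-MS, using NADPH, at 37 degrees C; on this read-out higher numbers stand for a longer-lived compound and lower numbers for a shorter-lived compound. There compound 1 gives > 0.5 h, which is a limit of the assay and not a number. Compound 3 `Cc1ccccc1-c1nc(CN2CCC(C(=O)NCCN3C[C@H](C)C[C@H](C)C3)CC2)c(C)o1` likewise gives > 0.5 h in this assay, again a limit and not a number. Among the measured compounds shown here, compound 2 `Cc1ccccc1-c1nc(CN2CCC(C(=O)NCCCN3CCC(C(C)C)CC3)CC2)c(C)o1` gives 0.147 h in this assay, the one value in the set that is a number. For the measured compounds named here, the only step measured so far, an at least 3.4-fold higher number from compound 2 to compound 3 (0.53 log units; beyond the scatter), concerns the amine end of the chain, and its size is bounded by the limit of > 0.5 h in this assay, at which 2 of the 3 values shown sit.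

Compound 4 `Cc1oc(-c2c(Cl)cccc2C(F)(F)F)nc1CN1CCC(C(=O)NCCCN2C[C@H](C)C[C@H](C)C2)CC1` differs from compound 1 at the aryl group on the shared core: 2-chloro-6-(trifluoromethyl)phenyl in place of 2,4,6-trimethylphenyl on an aromatic carbon. Going by the values given here, no measured step touches this position, so the step from compound 1 to compound 4 has no direct precedent in this assay; the one measured step lies elsewhere in the molecule. With compound 1 at the limit, the expectation is that the half-life of compound 4 stays in the same region, that is a step that the limit leaves unreadable from compound 1 to compound 4 in this assay, and compound 4 is estimated at 0.6 h within a range of 0.2 h to 2 h.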

Compound 4, half-life: 0.03 h
For compound 4 the middle estimate is 20-fold (1.30 log units) above the measured one, and the stated range ends above it.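

In this assay, among the compounds shown here, the aryl position now carries a measured step, an at least 16-fold lower number from compound 1 to compound 4 (1.22 log units; beyond the scatter), where the one earlier step concerned only the amine end of the chain. Compound 4 keeps the chain and amine end of compound 1, so these alone do not secure a long half-life: compound 4 gives 0.03 h. The step gives only a lower bound on the size of the change, as its starting value is a limit and not a number: the limit of > 0.5 h in this assay, at which 2 of the 4 values shown sit.

Still open, on these data alone, is whether the chlorine or the trifluoromethyl group carries the drop, a question that a 2-chlorophenyl or a 2-(trifluoromethyl)phenyl group on the same chain would separate. Also open, as far as these compounds go, is how an aryl group without a halogen, such as an unsubstituted phenyl, would read at this position.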